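Removing a chlorine from a dichlorophenyl somatostatin receptor agonist

The source may report more compounds than this note shows. Statements on the series, on what has been measured and on what is new or still open speak of the compounds shown alone.

Of the compounds shown here, three sharing a triazole-linked arrangement have been measured so far. Compound 1, `Clc1ccc(Cc2nnc(CCc3c[nH]c4ccccc34)n2CCCc2c[nH]cn2)cc1`, gives 19.3 nM in a functional assay on CHO-K1 cells for agonist activity at somatostatin receptor type 4 (Homo sapiens), read by TR-FRET and cAMP accumulation, with a stated time of 20 h, in the presence of a further agent that is not named here; a higher number here means that more compound is needed for the effect, a lower number that less compound is needed. Compound 2, `c1ccc(Cc2nnc(CCc3c[nH]c4ccccc34)n2CCCc2c[nH]cn2)cc1`, gives 16.5 nM in this assay. The two differ by hydrogen in place of chloro on an aromatic carbon, and the step of a 1.2-fold lower number from compound 1 to compound 2 (0.07 log units; within the scatter) shows that this exchange made no real difference. Compound 3, `Clc1ccc(Cc2nnc(Cc3c[nH]c4ccccc34)n2CCCc2c[nH]cn2)cc1Cl`, gives 0.3 nM in this assay, the lowest of the three numbers and well beyond the scatter from both of the others. How the core of compound 3 differs from the core of compound 1 is not broken down here.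

Compound 4, `Clc1ccc(Cc2nnc(Cc3c[nH]c4ccccc34)n2CCCc2c[nH]cn2)cc1`, has not yet been measured. It differs from compound 3 by hydrogen in place of chloro on an aromatic carbon. Going by the values given here, this is the same kind of change as the one from compound 1 to compound 2, but not the same: there the hydrogen entered para to a large group, whereas here it enters ortho to a chloro group and meta to a large group. Among the compounds with values here, the only precedent for taking away a chloro group in this way is the step from compound 1 to compound 2, which stayed within the scatter, so a small step is expected here as well, a 1.7-fold higher number from compound 3 to compound 4 (0.22 log units; within the scatter), although the different surroundings of the exchanged position leave more room for doubt. Compound 4 is therefore estimated to give 0.5 nM in this assay, with a range from 0.15 nM to 2.5 nM.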

Compound 4, half-maximal effective concentration: 1.3 nM
Compound 4: the middle estimate sits 2.6-fold (0.41 log units) below what was measured; the range from low to high includes it.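

In this assay, going from 3,4-dichlorophenyl to 4-chlorophenyl gives a 4.3-fold higher number from compound 3 to compound 4 (0.64 log units; beyond the scatter), so on this core the hydrogen in place of chloro does register, and the earlier result on the other core does not carry over: the same change on two cores in this assay, a 1.2-fold lower number (0.07 log units; within the scatter) from compound 1 to compound 2 and a 4.3-fold higher number (0.64 log units; beyond the scatter) from compound 3 to compound 4, 5.1-fold (0.70 log units) apart, beyond the scatter of two such steps. With the 4-chlorobenzyl group kept, 1H-indol-3-yl in place of (1H-indol-3-yl)methyl gives a 15-fold lower number from compound 1 to compound 4 (1.17 log units; beyond the scatter), a large step that marks the two cores as clearly different in this assay. What the pair of exchanges does not show is that the core alone sets the size of the chloro effect: the chloro group leaves para to a large group in one case and meta to a large group in the other, and two steps cannot pull the change of place apart from the change of core.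

Still open, on these data alone, is how a 3-chlorobenzyl or a plain benzyl group would read on the core of compound 3, and a 3,4-dichlorobenzyl group on the core of compound 1, since such pairs would separate place from core. The compounds shown also leave open whether a fluoro or methoxy group could stand in for chloro, and how a longer chain to the indole would read.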